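The source may hold more compounds than are shown below. What is called first, only, known or untested is meant among the compounds shown, and "the series" means these compounds.

Compound 1 `CN(CCNCc1cn(-c2ccc(Cl)cc2)nn1)CCNc1ccnc2cc(Cl)ccc12` gives 14000 nM in a functional assay on NCI-H460 cells (Homo sapiens) for antiproliferative activity, read by sulforhodamine B assay, with a stated time of 72 h; on this read-out lower numbers stand for stronger inhibition and higher numbers for weaker inhibition. Compound 2 `CN(CCNCc1cn(CCCO)nn1)CCNc1ccnc2cc(Cl)ccc12` reaches only a limit in this assay, > 200000 nM. The one measured step, an at least 14-fold higher number from compound 1 to compound 2 (1.15 log units; beyond the scatter), sits at the limit of > 200000 nM in this assay, at which 1 of the 2 values shown sits, so compound 2 stands at the weak end of what is shown. Compound 3 `CN(CCNCc1cn(Cc2nc3cc(Cl)ccc3[nH]2)nn1)CCNc1ccnc2cc(Cl)ccc12` differs from compound 2 by 5-chloro-1H-benzimidazol-2-yl in place of 2-hydroxyethyl on a saturated chain carbon bound to an aromatic nitrogen: an aromatic group returns where compound 1 carried one. Within the data shown here, only the step from compound 1 to compound 2 bears on this change, and it was large; a gain of similar size is therefore expected, an at least 13-fold lower number from compound 2 to compound 3 (1.12 log units; beyond the scatter). Compound 3 is estimated at 15000 nM, between 4000 nM and 80000 nM.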

Compound 3, half-maximal inhibitory concentration: 59000 nM
The estimate for compound 3 lay 3.9-fold (0.59 log units) below the measured number, within the range that was stated.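

Replacing the 2-hydroxyethyl on this saturated chain carbon with 5-chloro-1H-benzimidazol-2-yl gives an at least 3.3-fold lower number from compound 2 to compound 3 (0.53 log units; beyond the scatter) in this assay and brings inhibition back to a measurable level. From the compounds shown here alone, the true size of that gain stays unknown, as compound 2 stands at a limit: the limit of > 200000 nM in this assay, at which 1 of the 3 values shown sits. The recovery is only partial, with a 4.2-fold higher number from compound 1 to compound 3 (0.62 log units; beyond the scatter) for (5-chloro-1H-benzimidazol-2-yl)methyl in place of 4-chlorophenyl on an aromatic nitrogen.

Open, going by these compounds, is how a plain phenyl, an amine or a carboxylic acid would behave at this place. Also open, on these data alone, is what the chlorine of the 5-chloro-1H-benzimidazol-2-yl group contributes.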